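This account rests on a few compounds, and the source may have more. Where it says the series, first, only, none or still open, it means among the compounds named here.

Of the compounds shown here, three with a shared core have been measured in a functional assay for agonist activity at Free fatty acid receptor 1 (Homo sapiens), read by FLIPR, in the presence of a further agent that is not named here; a lower number here means that less compound is needed, a higher number that more compound is needed for the effect. Compound 1, `O=C1NC(=O)C(Cc2ccc(Oc3ccc(C(F)(F)F)cc3Cl)cc2)S1`, gives 78 nM in this assay. Compound 2, `Cc1cc(Oc2ncc(C(F)(F)F)cc2Cl)ccc1CC1SC(=O)NC1=O`, gives 10 nM in this assay. Compound 3, `O=C1NC(=O)C(Cc2ccc(Cc3ccccc3)cc2)S1`, gives 9280 nM in this assay, the highest of the three numbers: compound 1 sits at a lower number, beyond the scatter, and compound 2 at a lower number still, also beyond the scatter. Compound 4, `O=C1NC(=O)C(Cc2ccc(CCc3ccccc3)cc2)S1`, is not yet measured. It differs from compound 3 in one place: benzyl in place of phenyl on a saturated chain carbon bound to an aromatic carbon. For the measured compounds named here, no measured pair shows this change, so its step size is unknown. The expected step, a 1.0-fold lower number from compound 3 to compound 4 (0.01 log units; within the scatter), is none beyond the scatter in either direction. Compound 4 is therefore estimated at 9000 nM, within 2500 nM to 35000 nM.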

Compound 4, half-maximal effective concentration: 1080 nM
Estimate against measurement, compound 4: 8.3-fold (0.92 log units) above; the measured number lies below the stated range.
By their numbers in this assay, from the lowest: compound 2; then compound 1; then compound 4; then compound 3.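

Benzyl in place of phenyl on a saturated chain carbon bound to an aromatic carbon gives an 8.6-fold lower number from compound 3 to compound 4 (0.93 log units; beyond the scatter), the first step read in this series. This position is therefore sensitive to a change of a single carbon in the link to the terminal aromatic ring. Nothing available explains this step.

From the compounds shown here alone, whether a longer chain such as phenylpropyl would extend the trend or reverse it remains open. Also open, going by these compounds, is how an ether oxygen or an amine in this link would compare with benzyl on the same core.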